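A few compounds are considered here, and "the series" means these few. Any claim that something is new, unique, unknown or untested is made for them only; others in the source may bear on it.

Working notes on the series.

Compound 2 `COc1ccc2ncc(S(=O)(=O)c3cc(F)cc(F)c3)c(N3CCC(C)CC3)c2c1` gives the lowest of the three measured numbers in an assay on isolated protein for displacement of a labelled ligand from metabotropic glutamate receptor 5 (Homo sapiens), with a stated time of 60 min, tested at 1 uM; on this read-out lower numbers stand for less inhibition and higher numbers for more inhibition at the one concentration tested (going by the name of the read-out): compound 2 gives 30%, whereas compound 1 `Cc1ccc2ncc(S(=O)(=O)c3cc(F)cc(F)c3)c(N3CCC(C)CC3)c2c1` gives 72% and compound 3 `CC1CCN(c2c(S(=O)(=O)c3cc(F)cc(F)c3)cnc3ccc(Cl)cc23)CC1` gives 93%. Both steps away from compound 2 are beyond the scatter: a number 42 percentage points lower from compound 1 to compound 2 (beyond the scatter) and a number 63 percentage points higher from compound 2 to compound 3 (beyond the scatter), with a number 21 percentage points higher from compound 1 to compound 3 (beyond the scatter) between the other two. All three of these steps concern the methyl, methoxy or chloro substituent on the shared core; none touches the difluorophenyl ring.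

Compound 4 `COc1ccc2ncc(S(=O)(=O)c3cccc(F)c3)c(N3CCC(C)CC3)c2c1` differs from compound 2 by hydrogen in place of fluoro on an aromatic carbon. Going by the values given here, no measured step bears on this position, so the only anchor is the value of compound 2 itself. With nothing to suggest a shift in either direction, the expected step in this assay is a number 2 percentage points lower from compound 2 to compound 4 (within the scatter), that is, none beyond the scatter. Compound 4 is therefore estimated at 28%, within a range from 8% to 50%, the width reflecting the absence of any comparator for this change.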

Compound 4, a percentage reported as inhibition, at one concentration (the size of the read-out at that concentration, not a potency): 68%
Estimate against measurement, compound 4: 40 percentage points below; the whole stated range lies below it.
By their numbers in this assay, from the lowest: compound 2; then compounds 4 and 1 (each within the scatter of the next); then compound 3.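

In this assay, going by these compounds alone, going from 3,5-difluorophenyl to 3-fluorophenyl gives a number 38 percentage points higher from compound 2 to compound 4 (beyond the scatter), so the ring that stayed fixed through the earlier compounds also affects this read-out, and a single fluoro on it matters. Hydrogen in place of fluoro on this aromatic carbon, meta to a fluoro group, gives a step printed as large, as is a number 42 percentage points lower from compound 1 to compound 2 (beyond the scatter) on the shared core, although this reading holds only with methoxy on that core. Nothing available explains the direction or the size of this step.

Among the compounds shown, neither compound 1 nor compound 3 has a 3-fluorophenyl partner, so it remains open whether the step carries over to methyl or chloro on the core. On these data alone, it is also open how a nitrile or an amine at this aromatic carbon would read.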